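Series notes: aryl swap on the diene core, step to compound 3

The source may report more compounds than this note shows. Statements on the series, on what has been measured and on what is new or still open speak of the compounds shown alone.

The shared core is seen in compound 1 `COc1ccccc1/C=c1/[nH]c(=O)/c(=C\c2ccccc2OC)n(C)c1=O`, which carries 2-methoxyphenyl on both exocyclic carbons and in a functional assay on K562 cells (Homo sapiens) for cytotoxicity, read by CCK-8 assay, with a stated time of 72 h (on this read-out lower numbers stand for stronger inhibition and higher numbers for weaker inhibition), gives 2200 nM. Compound 2 `C=CCn1c(=O)/c(=C\c2ccc(Cl)c(Cl)c2)[nH]c(=O)/c1=C\c1ccccc1OC` keeps one 2-methoxyphenyl and an allyl group but carries 3,4-dichlorophenyl on the other exocyclic carbon; in this assay compound 2 is reported as "not active" (no number reported), with no number given. Where compound 2 stands on the numbers is therefore only this: it falls outside the measured range that compound 1 occupies, and no step between the two can be sized.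

Compound 3 `C=CCn1c(=O)/c(=C\c2ccccc2C(F)(F)F)[nH]c(=O)/c1=C\c1ccccc1OC` differs from compound 2 in one place: 2-(trifluoromethyl)phenyl in place of 3,4-dichlorophenyl on a double-bonded chain carbon bound to an aromatic carbon. For the measured compounds named here, no measured step of this kind exists in the set, so the size and direction of the change in this assay cannot be taken from data. With compound 2 inactive and compound 1 the only numbered point, compound 3 is expected to remain weak, and any gain over compound 2 is expected to be modest at best. Compound 3 is estimated at 6000 nM, with a range from 1500 nM to 30000 nM.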

Compound 3, half-maximal inhibitory concentration: 2700 nM
The estimate for compound 3 lay 2.2-fold (0.35 log units) above the measured number; measured number inside the range.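

For the compounds shown here, no step from compound 2 to compound 3 can be read: compound 2 is reported as not active without a number, while compound 3 has one. No measurement bearing on a cause for this result is available. The compounds shown leave open how 3,4-dichlorophenyl and 2-(trifluoromethyl)phenyl compare in size of effect on an otherwise unchanged compound.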